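A Methoxy Group on a Compound at the Assay Limit

The source may report more compounds than this note shows. Statements on the series, on what has been measured and on what is new or still open speak of the compounds shown alone.

Compound 1 `CC(C)Nc1nc(NCc2ccco2)c2ccccc2n1` stands at >= 30000 nM in a physicochemical assay for solubility, at pH 2 (a higher number here means a more soluble compound, a lower number a less soluble compound), and this is a limit of the assay, not a number. Compound 2 `CSCCNc1nc(NC(C)C)nc2ccccc12` gives >= 30000 nM, also a limit. Compound 3 `CC(C)Nc1nc(NCc2ccco2)c2cc(Cl)ccc2n1` gives >= 30000 nM, likewise a limit. The measured set therefore amounts to the limit of >= 30000 nM in this assay, at which 3 of the 3 values shown sit.

Compound 4 `COc1ccc2c(NCc3ccco3)nc(NC(C)C)nc2c1` carries methoxy in place of hydrogen on an aromatic carbon. The closest measured change is chloro in place of hydrogen on an aromatic carbon, which gave a step that the two limits leave unreadable from compound 1 to compound 3. The other measured change, (methylsulfanyl)methyl in place of furan-2-yl on a saturated chain carbon bound to a nitrogen on an aromatic ring, gave a step that the two limits leave unreadable from compound 1 to compound 2. Neither step has a readable size, so neither provides a measure for the new group. Among the compounds with values here, both changed compounds nevertheless remained at the same limit as compound 1, and no measured compound has yet returned a number. The expectation is thus for no step beyond the scatter, in either direction. The expected step is a number no higher from compound 1 to compound 4 (the limit leaves the size open). Compound 4 is expected at 30000 nM, with an estimated range from 15000 nM to 45000 nM.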

Compound 4, solubility: >= 30000 nM
Compound 4: a limit, no number; the forecaster's own chance of this, stated with the estimate: 85%; the middle value lies on the limit itself.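

In this assay compound 4 gives >= 30000 nM, which is a limit and not a number. Compound 1 also stands at a limit, so the step to compound 4, methoxy in place of hydrogen on an aromatic carbon, cannot be read. The compounds shown leave open what size any of these changes has, for the set offers only this: the limit of >= 30000 nM in this assay, at which 4 of the 4 values shown sit.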